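The source may report more compounds than this note shows. Statements on the series, on what has been measured and on what is new or still open speak of the compounds shown alone.

The three measured compounds share a core carrying a benzylamine on one side and, on a ring nitrogen, a short chain that ends in an amide. In an assay for inhibition of acyl-CoA desaturase 1 (Rattus norvegicus), using microsomes (a lower number here means a stronger inhibitor, a higher number a weaker inhibitor), compound 3 `CC1Oc2ccc(NCc3ccc(Cl)c(Cl)c3)cc2N(CCNC(=O)CO)C1=O` gives 80 nM. Compound 2 `Cc1nc2ccc(NCc3cccc(C(F)(F)F)c3)cc2n(CCNC(=O)[C@H](C)O)c1=O` gives 8000 nM in this assay, the higher of the two plain numbers shown. The gap between compound 2 and compound 3 lies well beyond the usual scatter. Compound 1 `CC(C)(C)c1nc2ccc(NCc3cccc(C(F)(F)F)c3)cc2n(CCNC(=O)CO)c1=O` gives only > 3000 nM in this assay, which is a limit of the assay and not a number (the limit of > 3000 nM in this assay, at which 1 of the 3 values shown sits).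

Compound 4 `Cc1nc2ccc(NCc3cccc(C(F)(F)F)c3)cc2n(CCNC(N)=O)c1=O` differs from compound 2 in one place: amino in place of 1-hydroxyethyl on a carbonyl carbon, so the chain now ends in a urea rather than a hydroxy amide. Going by the values given here, no pair of measured compounds shows this kind of exchange, so its effect cannot be read from the numbers at hand. The expected step of a 1.3-fold higher number from compound 2 to compound 4 (0.10 log units; within the scatter) is small, in the direction of a slightly weaker inhibitor, and no larger than the scatter. Compound 4 is therefore expected to give about 10000 nM in this assay, with a likely range from 3000 nM to 30000 nM.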

Compound 4, half-maximal inhibitory concentration: 15 nM
Compound 4: middle estimate off by 670-fold (2.82 log units), on the high side; measured number below the stated range.
By their numbers in this assay, from the lowest: compound 4; then compound 3; then compound 2.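

In this assay, the carbonyl carbon at the end of the chain proves to be a highly sensitive place: amino in place of 1-hydroxyethyl, which turns the ((1-hydroxyethyl)carbonyl)amino end into ureido, gives a 530-fold lower number from compound 2 to compound 4 (2.73 log units; beyond the scatter). This is the first step shown in which only one place differs, so the rest of the molecule stays fixed and the whole shift belongs to this exchange, in which 3 heavy atoms leave, 1 heavy atom enters and the defined stereocentre disappears. Nothing measured here accounts for the size of this step.

The compounds shown leave open which part of the exchange matters: the gain of the amino group, the loss of 1-hydroxyethyl, or the change from amide to urea, a question that a methylamino or dimethylamino group, or a plain methyl group, on the same carbonyl carbon could help to separate. They also leave open whether the ureido end gives a similar step on the cores of compound 1 and compound 3, and whether a longer chain between the ring nitrogen and the ureido group would keep the low number of compound 4.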